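Aryl to thiazolylmethyl on the ring nitrogen

The source may hold more compounds than are shown below. What is called first, only, known or untested is meant among the compounds shown, and "the series" means these compounds.

Among the measured compounds shown here, compound 2 `Cc1cc(Nc2nn(-c3ccc(F)cc3)c(=O)c3ccccc23)n[nH]1` gives 800 nM in a functional assay on HCT-116 cells (Homo sapiens) for cytotoxicity, read by CellTiter-Glo, with a stated time of 5 days (on this read-out higher numbers stand for weaker inhibition and lower numbers for stronger inhibition), and has the lowest of the two numbers so far; compound 1 `Cc1cc(Nc2nn(C)c(=O)c3ccccc23)n[nH]1` gives 5200 nM. For the measured compounds named here, the only comparable step is a 6.5-fold lower number from compound 1 to compound 2 (0.81 log units; beyond the scatter), which replaced methyl by 4-fluorophenyl on the aromatic nitrogen. Compound 3 `Cc1cc(Nc2nn(Cc3csc(C)n3)c(=O)c3ccccc23)n[nH]1` differs from compound 2 by (2-methyl-1,3-thiazol-4-yl)methyl in place of 4-fluorophenyl on an aromatic nitrogen: a methylene-linked five-membered ring takes the place of the six-membered aromatic ring. Going by the values given here, no measured step covers this exact change. Since compound 1 with methyl gives 5200 nM and compound 2 with the aryl gives 800 nM, compound 3 is expected to land between them, a step of a 2.5-fold higher number from compound 2 to compound 3 (0.40 log units; beyond the scatter). Estimate for compound 3: 2000 nM, range 600 nM to 6000 nM.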

Compound 3, half-maximal inhibitory concentration: 4180 nM
The estimate for compound 3 lay 2.1-fold (0.32 log units) below the measured number, and the stated range covers the measured number.
By their numbers in this assay, from the lowest: compound 2; then compounds 3 and 1 (each within the scatter of the next).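

On the aromatic nitrogen, the drop in the number seen with 4-fluorophenyl does not carry over to (2-methyl-1,3-thiazol-4-yl)methyl, with a 5.2-fold higher number from compound 2 to compound 3 (0.72 log units; beyond the scatter) as the step. Against the methyl group, a 1.2-fold lower number from compound 1 to compound 3 (0.09 log units; within the scatter) shows that adding the 2-methyl-1,3-thiazol-4-yl ring to that saturated chain carbon gives no separation from compound 1. The compounds shown leave open whether the aromatic ring needs direct attachment to the nitrogen or a different ring would do, and a benzyl group would test this against 4-fluorophenyl. No measured evidence bears on the reason for this result.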